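Methyl on the triazole of compound 3

A few compounds are considered here, and "the series" means these few. Any claim that something is new, unique, unknown or untested is made for them only; others in the source may bear on it.

Measured so far:
- compound 1, `CC(C)C(Nc1nnc[nH]1)c1ccc(-c2ccc3cccc(F)c3c2)[nH]c1=O`: 22 nM
- compound 2, `CC(C)C(O)(C(=O)O)c1ccc(-c2ccc3ccccc3c2)[nH]c1=O`: 544 nM
- compound 3, `CCn1ncc2c(F)cc(-c3ccc(C(CC)(CC)c4nnc[nH]4)c(=O)[nH]3)cc21`: 17 nM

All three were tested in an assay on CHO cells for displacement of a labelled ligand from prostaglandin E2 receptor EP3 subtype (Homo sapiens), read by radioligand binding; on this read-out lower numbers stand for stronger inhibition and higher numbers for weaker inhibition. Compound 3 gives 17 nM, a number that compound 1 with 22 nM matches within the usual scatter, so the two cannot be told apart, while compound 2 with 544 nM stands far higher, beyond the scatter. Compound 3 is thus among the compounds with the lower numbers in this set.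

Compound 4, `CCn1ncc2c(F)cc(-c3ccc(C(CC)(CC)c4nnc(C)[nH]4)c(=O)[nH]3)cc21`, is not yet measured. It differs from compound 3 in one place: methyl in place of hydrogen on an aromatic carbon. The methyl sits on the triazole ring, between two ring nitrogen atoms, away from the part of the molecule that compounds 1 and 2 vary. Going by the values given here, no measured pair in this set shows what such a small addition does, so the expectation rests on the change being a single carbon on a ring edge. The step from compound 3 to compound 4 in this assay is expected to be small, a 1.5-fold higher number from compound 3 to compound 4 (0.17 log units; within the scatter), likely not beyond the scatter in either direction. Compound 4 is therefore expected to give 25 nM, with a range from 8 nM to 80 nM.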

Compound 4, inhibition constant in the prostaglandin E2 receptor EP3 subtype assay: 34 nM
Estimate against measurement, compound 4: 1.4-fold (0.13 log units) below, and the stated range covers the measured number.
By their numbers in the prostaglandin E2 receptor EP3 subtype assay, from the lowest: compounds 3, 1 and 4 (each within the scatter of the next); then compound 2.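

Going by these compounds alone, the triazole carbon between two ring nitrogen atoms can carry a methyl: in the prostaglandin E2 receptor EP3 subtype assay compound 3 gives 17 nM and compound 4 gives 34 nM after the exchange of hydrogen for methyl, which is a 2.0-fold higher number from compound 3 to compound 4 (0.30 log units; within the scatter), the first one-place step in this set, and it cannot be told from repeat scatter. In a physicochemical assay for solubility, measured as kinetic solubility, at pH 2 (a lower number here means a less soluble compound, a higher number a more soluble compound), compound 3 gives 39100 nM and compound 4 gives 33900 nM after the same exchange, which is a 1.2-fold lower number from compound 3 to compound 4 (0.06 log units; within the scatter), so neither read-out separates the two compounds. Nothing shown here explains how the methyl is accommodated at this position.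

On these data alone, what stays open is whether the position accepts only a methyl or also larger or different groups, such as an ethyl, a trifluoromethyl, an amine or a carboxylic acid on the same ring carbon. One step also cannot show whether a methyl at this place would read the same way on the core of compound 1.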